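The source may hold more compounds than are shown below. What is called first, only, known or untested is meant among the compounds shown, and "the series" means these compounds.

Measured so far in a functional assay on CCRF-CEM cells (Homo sapiens) for cytotoxicity; on this read-out lower numbers stand for stronger inhibition and higher numbers for weaker inhibition: compound 1 `O=C(/C=C/C(=O)N1C/C(=C\c2ccccc2)C(=O)/C(=C/c2ccccc2)C1)Nc1ccccc1` gives 1100 nM; compound 2 `Cc1ccc(NC(=O)/C=C/C(=O)N2C/C(=C\c3ccc([N+](=O)[O-])cc3)C(=O)/C(=C/c3ccc([N+](=O)[O-])cc3)C2)cc1` gives 890 nM; compound 3 `CC(=O)c1ccc(NC(=O)/C=C/C(=O)N2C/C(=C\c3ccccc3)C(=O)/C(=C/c3ccccc3)C2)cc1` gives 1700 nM.

Compound 3 holds the highest of the three numbers, but its gaps to compound 1 and to compound 2 both lie within the scatter, so no order can be read among them. Compound 4 `O=C(/C=C/C(=O)N1C/C(=C\c2ccccc2)C(=O)/C(=C/c2ccccc2)C1)Nc1ccc([N+](=O)[O-])cc1` differs from compound 3 by nitro in place of acetyl on an aromatic carbon, the change read one bond further out as (4-acetylphenyl)carbamoyl to (4-nitrophenyl)carbamoyl. Among the measured compounds shown here, the only measured step at this aromatic carbon is a 1.5-fold higher number from compound 1 to compound 3 (0.19 log units; within the scatter). For the measured compounds named here, no measured step exchanges acetyl for nitro; compound 2 also bears nitro groups and sits within the scatter of compound 3. A step within the scatter is therefore expected, a 1.3-fold lower number from compound 3 to compound 4 (0.12 log units; within the scatter). Compound 4 is estimated at 1300 nM, range 500 nM to 3500 nM.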

Compound 4, half-maximal inhibitory concentration: 40000 nM
Compound 4: middle estimate off by 31-fold (1.49 log units), on the low side; the whole stated range lies below it.
By their numbers in this assay, from the lowest: compounds 2, 1 and 3 (each within the scatter of the next); then compound 4.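

The step of a 24-fold higher number from compound 3 to compound 4 (1.37 log units; beyond the scatter) and the step of a 36-fold higher number from compound 1 to compound 4 (1.56 log units; beyond the scatter) show that this aromatic carbon, para to a large group, is sensitive to the group it carries: acetyl stayed within the scatter of hydrogen, but nitro does not. Acetyl and nitro match in heavy-atom count, so that count does not separate them. Nothing shown accounts for this loss.

From the compounds shown here alone, whether the loss is specific to nitro remains open; an amine, a carboxylic acid or chlorine at this carbon would test how far it extends. Also open, going by these compounds, is whether moving nitro elsewhere on this ring preserves it.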